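Swapping a furan ring for a benzyloxy group on a carbonyl

The source may report more compounds than this note shows. Statements on the series, on what has been measured and on what is new or still open speak of the compounds shown alone.

Measured so far:
- compound 1, `Cn1cncc1CN1CC(N(CC2CCN(C(=O)c3ccco3)CC2)S(=O)(=O)c2ccccn2)Cc2cc(C#N)ccc21`: 0.5 10^-6 cm/s
- compound 2, `Cn1cncc1CN1CC(N(Cc2cccc(-n3cccc3)c2)S(=O)(=O)c2ccccn2)Cc2cc(C#N)ccc21`: 2.3 10^-6 cm/s
- compound 3, `Cn1cnc(S(=O)(=O)N(CCn2cccc2)C2Cc3cc(C#N)ccc3N(Cc3cncn3C)C2)c1`: 0.3 10^-6 cm/s

These three compounds share a core and were tested in an ADME assay on Caco-2 cells (Homo sapiens) for permeability, in the apical to basolateral direction; a lower number here means that the compound crosses the layer more slowly, a higher number that the compound crosses the layer faster. Compound 1 stands second highest of the three numbers; its value and that of compound 3 lie within the scatter of each other, so no order between them can be claimed, while compound 2 gives a number beyond the scatter above compound 1.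

The compound now in view is compound 4, `Cn1cncc1CN1CC(N(CC2CCN(C(=O)OCc3ccccc3)CC2)S(=O)(=O)c2ccccn2)Cc2cc(C#N)ccc21`. It differs from compound 1 in one place: benzyloxy in place of furan-2-yl on a carbonyl carbon. Read one bond further out, the change is a (furan-2-yl)carbonyl becoming a benzyloxycarbonyl. Going by the values given here, no pair of measured compounds shows this change, so nothing in these numbers sets its size.

The expected step of a 2.0-fold higher number from compound 1 to compound 4 (0.30 log units; within the scatter) is small, upward, and within the scatter. Compound 4 is expected to give 1 10^-6 cm/s in this assay, with a range from 0.3 10^-6 cm/s to 3 10^-6 cm/s.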

Compound 4, apparent permeability: 1 10^-6 cm/s
Compound 4: middle estimate and measured number agree at the digits printed; the range from low to high includes it.
By their numbers in this assay, from the lowest: compounds 3, 1 and 4 (each within the scatter of the next, the first and the last beyond it); then compound 2.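

Going by these compounds alone, this step gives the first reading at this position: benzyloxy in place of furan-2-yl on a carbonyl carbon comes with a 2.0-fold higher number from compound 1 to compound 4 (0.30 log units; within the scatter) in this assay. Here, a group of 8 heavy atoms with a six-membered aromatic ring of carbon only replaces one of 5 heavy atoms with a five-membered aromatic ring, and the result cannot be told apart from the scatter of repeated measurements. No measurement shown here explains the size of this step.

A single step cannot show how much of it belongs to the ring and how much to the oxygen that joins the benzyl part to the carbonyl. On these data alone, what a simple amine, or a longer chain ending in a phenyl ring, would give on this carbonyl carbon remains open.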